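Pyridin-2-yl in place of 4-methylphenyl on a shared core

The source may hold more compounds than are shown below. What is called first, only, known or untested is meant among the compounds shown, and "the series" means these compounds.

Of the compounds shown here, two with the same core have been tested in a functional assay on SW480 cells (Homo sapiens) for cytotoxicity, read by MTT assay, with a stated time of 4 days; a higher number here means a weaker inhibitor, a lower number a stronger inhibitor. Compound 1 `C=C1C[C@]23C[C@@]1(O)CC[C@H]2c1ccc(OS(=O)(=O)c2ccc(C)cc2)c(C)c1[C@@H]3Cn1cc(-c2ccc(Br)cc2)nn1` gives > 20000 nM, which is a limit of the assay rather than a measured number. Compound 2 `C=C1C[C@]23C[C@@]1(O)CC[C@H]2c1cc(Br)c(O)c(C)c1[C@@H]3Cn1cc(-c2ccc(C)cc2)nn1` gives > 20000 nM, likewise a limit and not a number. Within the data shown here, compound 2 therefore stands at the assay limit, a position shared by every value so far, as the limit of > 20000 nM in this assay, at which 2 of the 2 values shown sit, records.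

Compound 3 `C=C1C[C@]23C[C@@]1(O)CC[C@H]2c1cc(Br)c(O)c(C)c1[C@@H]3Cn1cc(-c2ccccn2)nn1` differs from compound 2 in a single place: pyridin-2-yl in place of 4-methylphenyl on an aromatic carbon. Among the measured compounds shown here, no step between two measured compounds exists to guide the direction of this change. Since both measured compounds sit at the limit, no move beyond the usual scatter is expected in this assay from this exchange, and compound 3 is expected to remain weak. Compound 3 is estimated at 20000 nM, with a range from 8000 nM to 50000 nM. The expected step of a number no higher from compound 2 to compound 3 (the limit leaves the size open) is essentially none.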

Compound 3, half-maximal inhibitory concentration: > 20000 nM
Compound 3 gave a limit, no number; the forecaster's own chance of this, stated with the estimate: 75%; the middle value lies on the limit itself.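

Among these compounds, no step from compound 2 to compound 3 can be read in this assay, since each gives only a limit of the assay: the limit of > 20000 nM in this assay, at which 3 of the 3 values shown sit. The compounds shown leave open whether exchanging 4-methylphenyl for pyridin-2-yl changes cytotoxicity in any compound that gives a real number.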